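Swapping the Aryl Group: From Fluoro to Dimethyl

The compounds below may be only part of what the source reports. "The series", "measured", "known", "first", "only" and "open" are said of these compounds alone.

Three analogues sharing one core were tested in a functional assay on KBVIN cells (Homo sapiens) for antiproliferative activity, read by sulforhodamine B assay, with a stated time of 3 days; on this read-out lower numbers stand for an effect already at smaller amounts and higher numbers for an effect only at larger amounts of compound. Compound 1 `CCC1=C(O)c2c(oc(-c3cccc(C(F)(F)F)c3)cc2=O)C(CC)(CC)C1=O` gives 5.42 uM, compound 2 `CCC1=C(O)c2c(oc(-c3cccc(F)c3)cc2=O)C(CC)(CC)C1=O` gives 3.09 uM, and compound 3 `CCC1=C(O)c2c(oc(-c3ccc(OC)c(OC)c3)cc2=O)C(CC)(CC)C1=O` gives 1 uM. Compound 2 thus holds the second highest of the three numbers: its nearest neighbour is compound 1, reached by a 1.8-fold lower number from compound 1 to compound 2 (0.24 log units; within the scatter), while compound 3 sits furthest away, its value lower than that of compound 2 by a gap beyond the scatter.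

The next compound, compound 4 `CCC1=C(O)c2c(oc(-c3cc(C)ccc3C)cc2=O)C(CC)(CC)C1=O`, differs from compound 2 by 2,5-dimethylphenyl in place of 3-fluorophenyl on an aromatic carbon. Among the compounds with values here, only one measured step bears on this change, a 1.8-fold lower number from compound 1 to compound 2 (0.24 log units; within the scatter), which also exchanged the group on the same aromatic carbon and stayed within the scatter. Within the data shown here, no measured step introduces a dimethyl-substituted ring, so the data give no firm direction. The writer therefore expects a 1.0-fold lower number from compound 2 to compound 4 (0.01 log units; within the scatter) to be modest, likely within the scatter. In this assay compound 4 is estimated at 3 uM, with a plausible range from 1 uM to 9 uM.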

Compound 4, concentration for half-maximal effect: 3.41 uM
Compound 4: middle estimate off by 1.1-fold (0.06 log units), on the low side, and the stated range covers the measured number.
By their numbers in this assay, from the lowest: compound 3; then compounds 2, 4 and 1 (each within the scatter of the next).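

In this assay, 2,5-dimethylphenyl in place of 3-fluorophenyl on the aromatic carbon next to the ring oxygen gives a 1.1-fold higher number from compound 2 to compound 4 (0.04 log units; within the scatter), so the two groups cannot be told apart at this position. The earlier step, a 1.8-fold lower number from compound 1 to compound 2 (0.24 log units; within the scatter), exchanged one fluorine-bearing group for another, whereas this change shows that a ring with no fluorine and with methyl groups instead also gives a number within the scatter of compound 2. Nothing available here explains why this exchange leaves the number within the scatter.

The compounds shown do not tell whether either methyl group of the 2,5-dimethylphenyl matters on its own. They also leave open whether a phenyl ring carrying an amine or a carboxylic acid would stay within this range or approach compound 3 at 1 uM.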